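Swapping the sulfonyl aryl group on a ring-bound sulfonamide

The source may hold more compounds than are shown below. What is called first, only, known or untested is meant among the compounds shown, and "the series" means these compounds.

Compound 1 `C=C(CC)C(=O)c1ccc(OCC(=O)NCCNS(=O)(=O)c2cc(Cl)ccc2OC)c(Cl)c1Cl` and compound 2 `C=C(CC)C(=O)c1ccc(OCC(=O)NCCNS(=O)(=O)c2ccc([N+](=O)[O-])cc2)c(Cl)c1Cl` share a core and differ only in 4-nitrophenyl in place of 5-chloro-2-methoxyphenyl on a sulfonyl sulfur. In a functional assay on HL-60 cells (Homo sapiens) for cytotoxicity, read by luminescence (on this read-out higher numbers stand for weaker inhibition and lower numbers for stronger inhibition), compound 1 gives 1600 nM, while compound 2 gives 580 nM, a step of a 2.8-fold lower number from compound 1 to compound 2 (0.44 log units; beyond the scatter). Compound 3 `C=C(CC)C(=O)c1ccc(OCC(=O)NC2CCN(S(=O)(=O)c3cc(Cl)ccc3OC)CC2)c(Cl)c1Cl` gives 700 nM; the difference between its core and that of compound 1 is not broken down here. Compound 4 `C=C(CC)C(=O)c1ccc(OCC(=O)NC2CCN(S(=O)(=O)c3ccc([N+](=O)[O-])cc3)CC2)c(Cl)c1Cl` has not yet been measured, and it differs from compound 3 by 4-nitrophenyl in place of 5-chloro-2-methoxyphenyl on a sulfonyl sulfur. The place is not the same in every word: in compound 1 the sulfonyl sulfur sits on a sulfonamide nitrogen, in compound 3 on a sulfonamide nitrogen in a ring, so this is the same kind of change rather than the same change. Among the measured compounds shown here, a step of about a 2.5-fold lower number from compound 3 to compound 4 (0.40 log units; beyond the scatter) is expected for compound 4, because the only measured example of this kind of change, a 2.8-fold lower number from compound 1 to compound 2 (0.44 log units; beyond the scatter), gave a modest lowering. On that basis compound 4 is estimated at 280 nM, with a likely range from 120 nM to 700 nM.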

Compound 4, half-maximal inhibitory concentration: 2470 nM
Compound 4: middle estimate off by 8.8-fold (0.95 log units), on the low side; measured number outside the range, above it.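

In this assay, replacing 5-chloro-2-methoxyphenyl with 4-nitrophenyl gives a 3.5-fold higher number from compound 3 to compound 4 (0.55 log units; beyond the scatter), so the change runs in the opposite direction from the earlier step and the two cores do not respond alike: the same change on two cores in this assay, a 2.8-fold lower number (0.44 log units; beyond the scatter) from compound 1 to compound 2 and a 3.5-fold higher number (0.55 log units; beyond the scatter) from compound 3 to compound 4, 9.7-fold (0.99 log units) apart, beyond the scatter of two such steps.
Within this series, then, a step measured on one core cannot simply be carried over to the other, in either size or direction. This does not show why the cores differ, and a single pair on each core gives no rule for other cores or other groups on the sulfonyl sulfur.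

The compounds shown leave open how a plain phenyl or a methyl on the sulfonyl sulfur would behave on each core. They also leave open whether the chlorine, the methoxy or the nitro group matters most to the reversal.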